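The source may hold more compounds than are shown below. What is called first, only, known or untested is meant among the compounds shown, and "the series" means these compounds.

Working notes on a small set of enones examined in an ADME assay on LLC-MK2 cells (Macaca mulatta) for cytotoxicity, read by MTT assay, with a stated time of 48 h; a higher number here means that more compound is tolerated, a lower number that less compound is tolerated. Compound 1 `CC(=O)/C(C)=C/c1ccc([N+](=O)[O-])cc1` gives 266000 nM. Compound 2 `CC(=O)/C(C)=C/c1ccc(N(C)C)cc1` gives 150000 nM in this assay. The two differ by a single change, (dimethylamino in place of nitro on an aromatic carbon), and the resulting step, a 1.8-fold lower number from compound 1 to compound 2 (0.25 log units; within the scatter), is within the scatter, so the two values cannot be told apart.

Compound 3 `COc1ccc(/C=C(\C)C(=O)/C=C/c2ccc([N+](=O)[O-])cc2)cc1` gives 20100 nM in this assay; this is the lowest of the three numbers, and its gaps to compound 2 and to compound 1 both lie beyond the scatter. How the core of compound 3 differs from the core of compound 1 is not broken down here.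

Compound 4 `COc1ccc(/C=C(\C)C(=O)/C=C/c2ccc(N(C)C)cc2)cc1` is not yet measured. It is reached from compound 3 by dimethylamino in place of nitro on an aromatic carbon. This is the same kind of change as that from compound 1 to compound 2, not the same one: in compound 1 the group sits para to a group of 6 heavy atoms, whereas in compound 3 it sits para to a large group. For the measured compounds named here, the one measured instance of this change, a 1.8-fold lower number from compound 1 to compound 2 (0.25 log units; within the scatter), stayed within the scatter. The step from compound 3 to compound 4 is therefore expected to be small as well, a 1.4-fold lower number from compound 3 to compound 4 (0.16 log units; within the scatter), because a 1.8-fold lower number from compound 1 to compound 2 (0.25 log units; within the scatter) showed no shift beyond the scatter. Compound 4 is accordingly estimated at 14000 nM in this assay, with a range from 5000 nM to 40000 nM. Going by the values given here, the support is thin: only one measured pair carries the change, and the surroundings of the two places are not identical.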

Compound 4, half-maximal cytotoxic concentration: 411000 nM
Beside the measured number, compound 4's estimate is 29-fold (1.47 log units) below it; the whole stated range lies below it.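

In this assay, dimethylamino in place of nitro on an aromatic carbon is a large step on the core of compound 3 (a 20-fold higher number from compound 3 to compound 4 (1.31 log units; beyond the scatter)), so the quiet result on the smaller core does not predict the result on this larger one. Across the two available pairs, the outcome of this change depends on the core that carries it, and the two steps can be told apart: the same change on two cores in this assay, a 1.8-fold lower number (0.25 log units; within the scatter) from compound 1 to compound 2 and a 20-fold higher number (1.31 log units; beyond the scatter) from compound 3 to compound 4, 36-fold (1.56 log units) apart, beyond the scatter of two such steps. This does not show which part of the core of compound 3 is responsible, what lies behind the step, or how the change would behave on a third core, as two pairs give a contrast and not a rule for the series.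

Still open, as far as these compounds go, is whether the large step belongs to dimethylamino specifically or would also appear with another group in that place, such as a primary amine, a carboxylic acid or a longer alkylamino chain on the core of compound 3. Also open, from the compounds shown here alone, is which feature of that core the step depends on, for example whether it would persist with a hydroxyl group in place of the methoxy group.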